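A few compounds are considered here, and "the series" means these few. Any claim that something is new, unique, unknown or untested is made for them only; others in the source may bear on it.

Compound 1 `CCC(=O)N1CC2CC(C1)N2`: 180 nM
Compound 2 `O=C(C1CCC1)N1CC2CC(C1)N2`: 370 nM
Compound 3 `O=C([C@@H]1C[C@H]1F)N1CC2CC(C1)N2`: 53 nM

These three compounds share one core and differ only in the group carried on the carbonyl carbon. In an assay on CHO cells for agonist activity at Neuronal acetylcholine receptor; alpha3/alpha6/beta2/beta3 (Homo sapiens), read by FLIPR and calcium flux (a lower number here means that less compound is needed, a higher number that more compound is needed for the effect), compound 3 gives the lowest number of the three, and it stands apart: the steps of a 3.4-fold lower number from compound 1 to compound 3 (0.53 log units; beyond the scatter) and a 7.0-fold lower number from compound 2 to compound 3 (0.84 log units; beyond the scatter) both lie beyond the scatter, so compound 3 is clearly the most potent of the set as measured here.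

Compound 4 `C[C@H]1C[C@H]1C(=O)N1CC2CC(C1)N2` keeps that core and makes one change: 2-methylcyclopropyl in place of 2-fluorocyclopropyl on a carbonyl carbon. Among the measured compounds shown here, no measured pair swaps a fluorine for a methyl on a small ring, so the bearing of this change has to be read from the steps that alter the group on the carbonyl carbon, namely a 2.1-fold higher number from compound 1 to compound 2 (0.31 log units; beyond the scatter) and a 3.4-fold lower number from compound 1 to compound 3 (0.53 log units; beyond the scatter), each a modest shift in this assay. Since the three-membered ring is retained and only the fluorine is exchanged, the expected result is a modest rise in the number rather than a large one, although a result within the scatter of compound 3 cannot be excluded. Compound 4 is therefore estimated to give 100 nM in this assay, with a likely range of 35 nM to 300 nM. That estimate corresponds to an expected step of a 1.9-fold higher number from compound 3 to compound 4 (0.28 log units; within the scatter).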

Compound 4, half-maximal effective concentration: 2000 nM
The estimate for compound 4 lay 20-fold (1.30 log units) below the measured number; measured number above the stated range.
By their numbers in this assay, from the lowest: compound 3; then compound 1; then compound 2; then compound 4.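

In this assay, among the compounds shown here, replacing 2-fluorocyclopropyl with 2-methylcyclopropyl on the carbonyl carbon keeps the three-membered ring and the heavy-atom count, yet it gives a 38-fold higher number from compound 3 to compound 4 (1.58 log units; beyond the scatter), the largest step in the set, so the ring alone does not secure a low number and the single atom or group on it matters greatly. The ring with methyl also compares poorly with the groups without a three-membered ring: there is an 11-fold higher number from compound 1 to compound 4 (1.05 log units; beyond the scatter) and a 5.4-fold higher number from compound 2 to compound 4 (0.73 log units; beyond the scatter), which leaves compound 4 as the least potent of the four, behind both ethyl and cyclobutyl. Nothing available explains why this exchange has so large an effect.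

From the compounds shown here alone, it remains open whether the rise comes from losing the fluorine or from gaining the methyl. A plain cyclopropyl group on the carbonyl carbon would separate those two readings, and 2-chlorocyclopropyl or 2-hydroxycyclopropyl would show how other atoms on the ring fare.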